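Demethylation of one aryl methoxy group in compound 3

This account rests on a few compounds, and the source may have more. Where it says the series, first, only, none or still open, it means among the compounds named here.

Compound 3 `C=CC[C@H]1C[C@]2([C@@H](C)Cc3cc(OC)c(OC)cc3F)OCOC2=CC1=O` gives 14 nM in a functional assay on M14 cells (Homo sapiens) for antiproliferative activity, with a stated time of 72 h (on this read-out higher numbers stand for weaker inhibition and lower numbers for stronger inhibition), the lowest of the two numbers reported as numbers. Going by the values given here, compound 1 `C=CC[C@H]1C[C@]2([C@@H](C)Cc3ccc(OC)c(OC)c3)OCOC2=CC1=O` gives 110 nM in this assay, and the step of a 7.9-fold lower number from compound 1 to compound 3 (0.90 log units; beyond the scatter) is the only single-place change in the set. In this assay compound 2 `C=CC[C@H]1C[C@]2(C(C)Cc3ccc(F)cc3)OCOC2=CC1=O` gives > 20000 nM, a limit of the assay and not a number. Among the compounds with values here, compound 2 differs from compound 3 in more than one place, so no step is drawn from it; it is noted only that it sits at the limit of > 20000 nM in this assay, at which 1 of the 3 values shown sits.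

Compound 4 `C=CC[C@H]1C[C@]2([C@@H](C)Cc3cc(O)c(OC)cc3F)OCOC2=CC1=O` differs from compound 3 by hydrogen in place of methyl on an oxygen on an aromatic ring. Within the data shown here, no measured step touches an oxygen-bound methyl, so neither the size nor the direction of the change is fixed by the data. Among the measured compounds shown here, the one single-place step, a 7.9-fold lower number from compound 1 to compound 3 (0.90 log units; beyond the scatter), concerns an aromatic fluorine and does not carry over to this change. Without precedent, the expectation for compound 4 is a modest step, a 2.9-fold higher number from compound 3 to compound 4 (0.46 log units; beyond the scatter), with a higher number somewhat more likely than a lower one, and a wide range. Compound 4 is therefore estimated at 40 nM, expected to fall between 8 nM and 300 nM.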

Compound 4, half-maximal inhibitory concentration: 9 nM
Compound 4: middle estimate off by 4.4-fold (0.65 log units), on the high side, and the stated range covers the measured number.
By their numbers in this assay, from the lowest: compounds 4 and 3 (each within the scatter of the next); then compound 1. At a limit, above all of these: compound 2.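

In this assay, methoxy to hydroxy on this aromatic ring gives a 1.6-fold lower number from compound 3 to compound 4 (0.19 log units; within the scatter), so compound 3 and compound 4 cannot be told apart on this read-out. Going by these compounds alone, this is the first reading at this oxygen, as the only earlier single-place step, a 7.9-fold lower number from compound 1 to compound 3 (0.90 log units; beyond the scatter), concerns an aromatic fluorine; within the fluorinated pair, the methyl on this oxygen is therefore not required to retain a number at the level of compound 3, and a free hydroxy is accepted at this place. Nothing measured in the series bears on why the two numbers lie so close.

Open, going by these compounds, is whether the same exchange holds on the ring without fluorine, as in compound 1, and whether the remaining methoxy group of compound 4 can also give way to hydroxy. Within the data shown here, also open is how far this place accepts other groups, such as an amine, a carboxylic acid or a longer chain like ethoxy, since methoxy and hydroxy are the only two groups read here.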